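Trading the Bromine of Compound 3 for Two Hydroxyls

The source may report more compounds than this note shows. Statements on the series, on what has been measured and on what is new or still open speak of the compounds shown alone.

Measured so far:
compound 1 `O=c1c(-c2ccc(O)cc2)coc2cc(OCCCCBr)ccc12` gives 4000 nM
compound 2 `O=c1c(-c2ccc(O)cc2)coc2cc(OCCC3OCCCO3)ccc12` gives 7000 nM
compound 3 `O=c1c(-c2ccc(O)cc2)coc2cc(OCCCBr)ccc12` gives 150 nM

In an assay on isolated protein (Cricetulus griseus) for inhibition of Monoamine oxidase (Homo sapiens) (a lower number here means a stronger inhibitor, a higher number a weaker inhibitor), compound 3 holds the lowest of the three numbers, set apart by the steps of a 27-fold lower number from compound 1 to compound 3 (1.43 log units; beyond the scatter) and a 47-fold lower number from compound 2 to compound 3 (1.67 log units; beyond the scatter), both beyond the scatter. Compound 4 `O=c1c(-c2ccc(O)cc2)coc2cc(OCC(O)CO)ccc12` differs from compound 3 by 1,2-dihydroxyethyl in place of 2-bromoethyl on a saturated chain carbon bound to an oxygen on an aromatic ring. The two measured steps bear on it: lengthening the chain by one bromomethyl, and exchanging bromine for a larger ring with two oxygens, each moved the number strongly upward away from compound 3. Compound 4 is therefore expected to give a clearly higher number, estimated as a 27-fold higher number from compound 3 to compound 4 (1.43 log units; beyond the scatter). The estimate for compound 4 is 4000 nM, within a range of 800 nM to 20000 nM.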

Compound 4, half-maximal inhibitory concentration: 1700 nM
For compound 4 the middle estimate is 2.4-fold (0.37 log units) above the measured one; the range from low to high includes it.
By their numbers in this assay, from the lowest: compound 3; then compound 4; then compounds 1 and 2 (each within the scatter of the next).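

In this assay the change from 3-bromopropoxy to 2,3-dihydroxypropoxy gives an 11-fold higher number from compound 3 to compound 4 (1.05 log units; beyond the scatter) and so loses ground, yet compound 4 still stands clear of the other two chains, with a 4.1-fold lower number from compound 2 to compound 4 (0.61 log units; beyond the scatter) and with a 2.4-fold lower number from compound 1 to compound 4 (0.37 log units; beyond the scatter) as well. Bromine is thus not required for a number lower than those of compound 1 and compound 2, although compound 3 keeps the lowest number of the four. Going by these compounds, whether an amine or a carboxylic acid at the chain end would hold this level stays open. Nothing shown here explains these steps.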